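A few compounds are considered here, and "the series" means these few. Any claim that something is new, unique, unknown or untested is made for them only; others in the source may bear on it.

Compound 1 `COc1ccc2[nH]c(C(=O)N3CC(=O)N(Cc4ccccc4)[C@@H](CN4CCCCC4)C3)cc2c1` and compound 2 `O=C(c1cc2cc(C3CC3)ccc2[nH]1)N1CC(=O)N(Cc2ccccc2)[C@@H](CN2CCC(F)CC2)C1` share a core and were both tested in an ADME assay on microsomes from liver (Homo sapiens) for metabolic stability, with a stated time of 30 min, tested at 1 uM; a higher number here means that the compound lasts longer, a lower number that the compound disappears faster. In this assay compound 1 gives 0.283 h, the lower of the two numbers shown, and compound 2 gives 0.383 h, a gap that stays within the scatter. Compound 3 `COc1ccc2[nH]c(C(=O)N3CC(=O)N(Cc4ccccc4)[C@@H](COc4ccc(F)cc4)C3)cc2c1` differs from compound 1 by 4-fluorophenoxy in place of piperidin-1-yl on a saturated chain carbon bound to a saturated ring carbon. Going by the values given here, no measured pair shows this change; the expected step is a 1.4-fold lower number from compound 1 to compound 3 (0.15 log units; within the scatter), small and toward a shorter half-life, and need not exceed the scatter. Compound 3 is therefore estimated at 0.2 h, ranging from 0.08 h to 0.5 h.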

Compound 3, half-life: 0.317 h
Compound 3: the middle estimate sits 1.6-fold (0.20 log units) below what was measured, within the range that was stated.
By their numbers in this assay, from the lowest: compounds 1, 3 and 2 (each within the scatter of the next).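

In this assay, 4-fluorophenoxy in place of piperidin-1-yl on a saturated chain carbon bound to a saturated ring carbon gives a 1.1-fold higher number from compound 1 to compound 3 (0.05 log units; within the scatter) and so leaves the half-life within the scatter. Going by these compounds alone, this is the first single-place step at this position, which compounds 1 and 2, differing in more than one place, could not provide. Nothing available explains this result. The compounds shown leave open how a morpholine, a carboxylic acid or an unsubstituted phenoxy would read at this place. They also leave open whether the same change holds on the core of compound 2.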